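Trimming a tert-butyl group on a second pyrazole core

The source may hold more compounds than are shown below. What is called first, only, known or untested is meant among the compounds shown, and "the series" means these compounds.

Of the compounds shown here, three have been tested in a functional assay on the whole organism (strain Swiss albino) for inhibition, with Mus musculus as the target, read by paw edema, with stated times of 30 min and 360 min, at a dose of 100 mg/kg by the subcutaneous route; on this read-out higher numbers stand for more inhibition at the one dose given (going by the name of the read-out) and lower numbers for less inhibition. Compound 1, `Cc1ccc(-c2cc(C(=O)Oc3ccc(C(C)(C)C)cc3)n(Cc3ccccc3)n2)cc1`, gives 62%. Compound 2, `Cc1ccc(-c2cc(C(=O)Oc3ccc(C(C)C)cc3)n(Cc3ccccc3)n2)cc1`, is its close relative, and in this assay compound 2 gives 31.5%. Compound 3, `Cc1ccc(-c2cc(C(=O)Oc3ccc(C(C)(C)C)cc3)nn2Cc2ccccc2)cc1`, is built from the same atoms as compound 1 but joined differently, and in this assay compound 3 gives 58.7%. The difference between the two cores is not broken down here; what the numbers show is that compound 3 and compound 1 lie within the scatter of each other.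

The change from compound 1 to compound 2 is hydrogen in place of methyl on a saturated chain carbon bound to an aromatic carbon and two saturated chain carbons. It carried the step of a number 30.5 percentage points lower from compound 1 to compound 2 (beyond the scatter). The not yet measured compound 4, `Cc1ccc(-c2cc(C(=O)Oc3ccc(C(C)C)cc3)nn2Cc2ccccc2)cc1`, carries the same change on the core of compound 3: hydrogen in place of methyl on a saturated chain carbon bound to an aromatic carbon and two saturated chain carbons.

Compound 3 sits close to compound 1, and in this assay compound 3 gives 58.7%. Because the measured step is a number 30.5 percentage points lower from compound 1 to compound 2 (beyond the scatter), a similar drop is expected for compound 4, roughly a number 28.7 percentage points lower from compound 3 to compound 4 (beyond the scatter). That expectation rests on a single measured pair, so it is held loosely. Compound 4 is therefore expected to give about 30% in this assay, most likely between 15% and 48%.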

Compound 4, a percentage reported as inhibition, in the whole organism at one dose (the size of the read-out at that dose, not a potency): 47.8%
Compound 4: middle estimate off by 17.8 percentage points, on the low side, and the stated range covers the measured number.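

In this assay, replacing tert-butyl with isopropyl on the core of compound 3 gives a number 10.9 percentage points lower from compound 3 to compound 4 (beyond the scatter), so the number falls in the same direction as it did on the core of compound 1. The direction of the change carries from one core to the other, but its size does not: the same change on two cores in this assay, a number 30.5 percentage points lower (beyond the scatter) from compound 1 to compound 2 and a number 10.9 percentage points lower (beyond the scatter) from compound 3 to compound 4, 19.6 percentage points apart, beyond the scatter of two such steps This rests on just two matched pairs read at a single dose, so it shows that the size of this step depends on the core in these compounds, but it does not explain the difference or show how any other change would carry between the cores.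

The compounds shown leave open how either core would respond if the tert-butyl group were replaced by something other than isopropyl, such as a methoxy group, a carboxylic acid or a longer chain like n-butyl. They also leave open whether the gap between the two steps would persist with an amide in place of the ester, or at doses other than the one tested.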